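The source may report more compounds than this note shows. Statements on the series, on what has been measured and on what is new or still open speak of the compounds shown alone.

In an ADME assay on L02 cells (Homo sapiens) for inhibition, read by CCK-8 assay, with a stated time of 48 h (on this read-out lower numbers stand for stronger inhibition of growth and higher numbers for weaker inhibition of growth), compound 1 `Cc1ccccc1Nc1nc(Nc2ccc(N3CCN(C)CC3)cn2)ncc1Cl` gives 5980 nM, and compound 2 `CN1CCN(c2ccc(Nc3ncc(Cl)c(NCc4ccc(C(F)(F)F)cc4)n3)nc2)CC1` gives 26200 nM. Compound 3 `Cc1ccc(CNc2nc(Nc3ccc(N4CCN(C)CC4)cn3)ncc2Cl)cc1` reads > 100000 nM, which is a limit of the assay and not a number. Any reading for a further compound has to be set against (the limit of > 100000 nM in this assay, at which 1 of the 3 values shown sits).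

Compound 4 `COc1ccc(CNc2nc(Nc3ccc(N4CCN(C)CC4)cn3)ncc2Cl)cc1` differs from compound 3 by methoxy in place of methyl on an aromatic carbon, para to a large group (methoxy in place of methyl on an aromatic carbon); the same difference reads 4-methylbenzyl to 4-methoxybenzyl.

The closest measured change is at that same carbon: the step with an at least 3.8-fold higher number from compound 2 to compound 3 (0.58 log units; beyond the scatter) shows that a swap there can move the read-out beyond the scatter. The wider exchanges are a 4.4-fold higher number from compound 1 to compound 2 (0.64 log units; beyond the scatter) and an at least 16-fold higher number from compound 1 to compound 3 (1.22 log units; beyond the scatter), but they replace the whole 2-methylphenyl group and bear on this case less directly. Since compound 3 has only a limit, a change can appear only as a lower number, or not at all if compound 4 also ends at a limit. A modest move toward a lower number is therefore expected, estimated as an at least 1.4-fold lower number from compound 3 to compound 4 (0.15 log units; that floor lies within the scatter). For compound 4 the estimated value is 70000 nM, with an expected range of 20000 nM to 200000 nM.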

Compound 4, concentration for 50% growth inhibition: 12900 nM
Compound 4: the middle estimate sits 5.4-fold (0.73 log units) above what was measured; the measured number lies below the stated range.
By their numbers in this assay, from the lowest: compound 1; then compound 4; then compound 2. At a limit, above all of these: compound 3.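

In this assay, methoxy in place of methyl on this aromatic carbon gives an at least 7.7-fold lower number from compound 3 to compound 4 (0.88 log units; beyond the scatter), which shows that a single swap at this position can bring a 4-substituted benzyl compound back to a measurable number. The earlier compounds had shown only that trifluoromethyl and methyl differ here, whereas a 2.0-fold lower number from compound 2 to compound 4 (0.31 log units; beyond the scatter) now puts methoxy ahead of trifluoromethyl as well, so the three groups on this carbon run from methoxy through trifluoromethyl to methyl, which stands at the limit. Even the best of these benzyl compounds does not match the 2-methylphenyl group, as a 2.2-fold higher number from compound 1 to compound 4 (0.33 log units; beyond the scatter) shows, and compound 1 keeps the lowest number of the set.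

Compound 3 stands at a limit of the assay and not at a number, so the true size of its step remains unknown and only a floor can be read: the limit of > 100000 nM in this assay, at which 1 of the 4 values shown sits. The compounds shown leave open whether an amine, a hydroxyl, a chlorine or a carboxylic acid on this same carbon would fall inside or outside this order, and what causes that order.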